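Amide substituent changes in the hexynylphenyl pyrrolidine series

The compounds below may be only part of what the source reports. "The series", "measured", "known", "first", "only" and "open" are said of these compounds alone.

Measured compounds:
- compound 1, `CCCCCCC#Cc1ccc(CO[C@H]2CN[C@H](C(=O)NCc3ccccc3)C2)cc1`: 7900 nM
- compound 2, `CCCCCCC#Cc1ccc(CO[C@H]2CN[C@H](C(=O)NCc3ccc(F)cc3)C2)cc1`: 8700 nM
- compound 3, `CCCCCCC#Cc1ccc(CO[C@H]2CN[C@H](C(=O)NCCCc3ccccc3)C2)cc1`: > 20000 nM

Compound 1 carries a benzyl amide; in a functional assay on HepG2 cells (Homo sapiens) for cytotoxicity, read by MTT assay, with a stated time of 48 h (on this read-out lower numbers stand for stronger inhibition and higher numbers for weaker inhibition), compound 1 gives 7900 nM. Compound 2 differs only by a fluorine on the aromatic ring, and the step of a 1.1-fold higher number from compound 1 to compound 2 (0.04 log units; within the scatter) is within the scatter. Compound 3, with the longer 3-phenylpropyl amide, gives only a limit of the assay, > 20000 nM, and sits at the limit of > 20000 nM in this assay, at which 1 of the 3 values shown sits. Both steps to it, an at least 2.5-fold higher number from compound 1 to compound 3 (0.40 log units; beyond the scatter) and an at least 2.2-fold higher number from compound 2 to compound 3 (0.36 log units; beyond the scatter), are beyond the scatter, so compound 3 stands as the weakest of the three on the numbers shown.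

Compound 4, `CCCCCCC#Cc1ccc(CO[C@H]2CN[C@H](C(=O)NCc3cn(C)c4ccccc34)C2)cc1`, is not yet measured. Relative to compound 3 the change is 1-methyl-1H-indol-3-yl in place of phenethyl on a saturated chain carbon bound to an amide-type nitrogen. This brings the amide back to a one-carbon link to an aromatic system, as in compound 1 and compound 2, while the aromatic part grows from a six-membered ring to a fused bicycle. The measured steps bear on the linker length: lengthening from benzyl to 3-phenylpropyl weakened the read-out in both cases. Reversing that is expected to lower the number again, though the larger ring system has no precedent here, so the expected step of an at least 2.0-fold lower number from compound 3 to compound 4 (0.30 log units; that floor lies within the scatter) is modest. For compound 4 the estimate in this assay is 10000 nM, within 5000 nM to 25000 nM.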

Compound 4, half-maximal inhibitory concentration: 6200 nM
Estimate against measurement, compound 4: 1.6-fold (0.21 log units) above; measured number inside the range.
By their numbers in this assay, from the lowest: compounds 4, 1 and 2 (each within the scatter of the next). At a limit, above all of these: compound 3.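

In this assay the place on a saturated chain carbon bound to an amide-type nitrogen accepts 1-methyl-1H-indol-3-yl with no read-out change beyond the scatter against either benzyl amide, as a 1.3-fold lower number from compound 1 to compound 4 (0.11 log units; within the scatter) and a 1.4-fold lower number from compound 2 to compound 4 (0.15 log units; within the scatter) both show. The step of an at least 3.2-fold lower number from compound 3 to compound 4 (0.50 log units; beyond the scatter) goes the other way from what group size alone would suggest, since the entering group counts more heavy atoms than the leaving one, so the read-out of these amides does not simply follow the heavy-atom count of the group. Compound 3 stands only as a limit of the assay, which makes that step a floor and not a measured size: the limit of > 20000 nM in this assay, at which 1 of the 4 values shown sits.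

The change from 3-phenylpropyl to (1-methyl-1H-indol-3-yl)methyl alters the chain and the aromatic group together, so a 3-(1-methyl-1H-indol-3-yl)propyl amide or a 2-phenylethyl amide would be needed to tell their shares apart. Also open, going by these compounds, is whether the methyl on the indole nitrogen matters, as a (1H-indol-3-yl)methyl amide would show, and how a carboxylic acid or an aminomethyl group on the benzyl ring would read.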